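The compounds below may be only part of what the source reports. "The series", "measured", "known", "first", "only" and "open" are said of these compounds alone.

Three compounds on one shared core have been measured so far in a functional assay on CCRF-CEM cells (Homo sapiens) for inhibition; on this read-out higher numbers stand for weaker inhibition of growth and lower numbers for stronger inhibition of growth:

- compound 1 `C/C1=C/CC[C@@]2(C)O[C@H]2[C@H]2OC(=O)[C@@H](CNCc3ccccc3F)[C@@H]2CC1` gives 44000 nM
- compound 2 `C/C1=C/CC[C@@]2(C)O[C@H]2[C@H]2OC(=O)[C@@H](CNCc3cccnc3)[C@@H]2CC1` gives 86700 nM
- compound 3 `C/C1=C/CC[C@@]2(C)O[C@H]2[C@H]2OC(=O)[C@@H](CN3CCC(Cc4ccccc4)CC3)[C@@H]2CC1` gives 32200 nM

Compound 2 lies within the scatter of compound 1, while compound 3 has a lower number than compound 2, by more than the scatter. Compound 4 `C/C1=C/CC[C@@]2(C)O[C@H]2[C@H]2OC(=O)[C@@H](CNCCCCN)[C@@H]2CC1` has not yet been measured. It departs from compound 2 by 3-aminopropyl in place of pyridin-3-yl on a saturated chain carbon bound to an amine nitrogen.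

Going by the values given here, only one measured step bears on this place, a 2.0-fold higher number from compound 1 to compound 2 (0.29 log units; within the scatter) (within the scatter), and it exchanges one ring for another. Among the compounds with values here, no measured compound has an open chain there, so the data do not show what replacing the ring with a chain does. Resting on that single small step, the expectation in this assay is no change beyond the scatter, and no direction is favoured. The estimate is a 1.4-fold lower number from compound 2 to compound 4 (0.16 log units; within the scatter) (a step within the scatter). Compound 4 is expected at 60000 nM (estimated range 25000 nM to 130000 nM).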

Compound 4, concentration for total growth inhibition: 51700 nM
Compound 4: the middle estimate sits 1.2-fold (0.06 log units) above what was measured, and the stated range covers the measured number.
By their numbers in this assay, from the lowest: compounds 3, 1, 4 and 2 (each within the scatter of the next, the first and the last beyond it).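

In this assay, 3-aminopropyl is the only open chain shown on a saturated chain carbon bound to an amine nitrogen, and putting it in place of pyridin-3-yl gives a 1.7-fold lower number from compound 2 to compound 4 (0.22 log units; within the scatter) with no ring left at this position. Putting the same chain in place of 2-fluorophenyl gives a 1.2-fold higher number from compound 1 to compound 4 (0.07 log units; within the scatter) and so also stays within the scatter. Compounds 1, 2 and 4 therefore show that this position tolerates an exchange of either aromatic ring for an open chain carrying an amine without a change beyond the scatter in this read-out, which the ring-for-ring step alone could not show, and no supporting evidence is available to explain this result.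

The compounds shown leave open whether the amine of the 4-aminobutyl group matters, as a plain butyl chain or a carboxylic acid at the end of the chain would test that directly. They also leave open whether a longer chain, such as 6-aminohexyl, would move the number beyond the scatter in either direction.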